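Inverted stereocentres in an inactive scaffold

A few compounds are considered here, and "the series" means these few. Any claim that something is new, unique, unknown or untested is made for them only; others in the source may bear on it.

The account concerns compound 1 `O=C1[C@@H]2C(c3ccccc3)OC3(C(=O)c4ccccc4C3=O)[C@@H]2C(=O)N1c1ccc(Cl)c(Cl)c1` and compound 3 `O=C1[C@H]2C(c3ccccc3)OC3(C(=O)c4ccccc4C3=O)[C@H]2C(=O)N1c1ccc(Cl)c(Cl)c1`, both measured or to be measured in an assay on isolated protein for inhibition of phenylalanine--tRNA ligase, mitochondrial (Homo sapiens); a lower number here means a stronger inhibitor, a higher number a weaker inhibitor. In this assay compound 1 gives only a limit, > 100000 nM, and no number. Within the data shown here, the single measured step, a step that the two limits leave unreadable from compound 1 to compound 2, leads to compound 2 `COc1ccc(N2C(=O)[C@@H]3C(c4ccccc4)OC4(C(=O)c5ccccc5C4=O)[C@@H]3C2=O)cc1`, which also returns only a limit, > 100000 nM, in this assay. That step therefore has no readable size, because the limit of > 100000 nM in this assay, at which 2 of the 2 values shown sit, holds for every value shown. Compound 1 thus stands at the edge of what this assay can report, and nothing yet places it within the measurable range.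

Compound 3 differs from compound 1 in that (the two compounds have the same atoms and bonds; at least one stereo element is drawn with a configuration in one of them and without one in the other: 2 of 3 stereo elements differ; a stereocentre at a saturated ring carbon is drawn S in compound 1 and R in compound 3; a stereocentre at a saturated ring carbon is drawn R in compound 1 and S in compound 3). Among the measured compounds shown here, no measured step bears on such a change, and the one step that exists is itself unreadable. The expectation for compound 3 is therefore that it remains at the same limit as compound 1, so that the expected step of a number no higher from compound 1 to compound 3 (the limit leaves the size open) cannot be read either. On that basis compound 3 is estimated at 100000 nM in this assay, with a range from 30000 nM to 300000 nM.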

Compound 3, half-maximal inhibitory concentration: > 100000 nM
Compound 3: a limit, no number; the forecaster's own chance of this, stated with the estimate: 80%; the middle value lies on the limit itself.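

In this assay compound 3 gives > 100000 nM as a limit and not a number. Among these compounds, compound 1 stands at the same limit, so no step from compound 1 to compound 3 can be read: the limit of > 100000 nM in this assay, at which 3 of the 3 values shown sit. The compounds shown leave open whether inverting these stereocentres changes inhibition at all, and whether any compound here inhibits measurably.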